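From pyrrolidin-1-yl to hexylamino on the shared core

The source may hold more compounds than are shown below. What is called first, only, known or untested is meant among the compounds shown, and "the series" means these compounds.

Compound 1 `CCCCCCCCNC(=O)/C=C/c1c(/C=C/c2ccc(OC)cc2)cc(OC)cc1OC`: 4280 nM
Compound 2 `CCCCNC(=O)/C=C/c1c(/C=C/c2ccc(OC)cc2)cc(OC)cc1OC`: 1330 nM
Compound 3 `COc1ccc(/C=C/c2cc(OC)cc(OC)c2/C=C/C(=O)N2CCCC2)cc1`: 4200 nM

In a functional assay on MCF7 cells (Homo sapiens) for inhibition, read by MTT assay, with a stated time of 48 h (a higher number here means a weaker inhibitor, a lower number a stronger inhibitor), compound 3 gives 4200 nM, which lies within the scatter of compound 1 at 4280 nM. Compound 2 stands apart from both at 1330 nM.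

The next compound is compound 4 `CCCCCCNC(=O)/C=C/c1c(/C=C/c2ccc(OC)cc2)cc(OC)cc1OC`, which carries hexylamino in place of pyrrolidin-1-yl on a carbonyl carbon.

Among the measured compounds shown here, three measured steps bear on this change. Swapping octylamino for pyrrolidin-1-yl moved nothing beyond the scatter, with a 1.0-fold lower number from compound 1 to compound 3 (0.01 log units; within the scatter). Swapping butylamino for pyrrolidin-1-yl was a modest step, with a 3.2-fold higher number from compound 2 to compound 3 (0.50 log units; beyond the scatter). The hexylamino chain is longer than the butylamino of compound 2 and shorter than the octylamino of compound 1, and those two differ by a 3.2-fold lower number from compound 1 to compound 2 (0.51 log units; beyond the scatter). Compound 4 is therefore expected to fall between them, although two chain lengths do not establish a trend. The expected step is a 1.8-fold lower number from compound 3 to compound 4 (0.24 log units; within the scatter), leaning towards a lower number but not clearly beyond the scatter. For compound 4 the estimated value is 2400 nM, with an expected range from 1200 nM to 4800 nM.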

Compound 4, half-maximal inhibitory concentration: 5530 nM
Beside the measured number, compound 4's estimate is 2.3-fold (0.36 log units) below it; the whole stated range lies below it.
By their numbers in this assay, from the lowest: compound 2; then compounds 3, 1 and 4 (each within the scatter of the next).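

In this assay, replacing the pyrrolidin-1-yl ring with the open hexylamino chain on the carbonyl carbon moves nothing beyond the scatter, with a 1.3-fold higher number from compound 3 to compound 4 (0.12 log units; within the scatter), so gaining the amide hydrogen and losing the ring do not on their own shift the number at this position. The hexylamino chain also stays within the scatter of octylamino, with a 1.3-fold higher number from compound 1 to compound 4 (0.11 log units; within the scatter), whereas extending butylamino by an ethyl gives a 4.2-fold higher number from compound 2 to compound 4 (0.62 log units; beyond the scatter), so the gap between the two earlier chain lengths already appears at hexylamino and no gradual rise runs across the three chains. Nothing measured here accounts for butylamino standing apart from the other three groups.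

The compounds shown leave open whether the lower number belongs to butylamino alone or extends to shorter and intermediate chains such as ethylamino, propylamino or pentylamino. They also leave open whether a six-membered ring such as piperidin-1-yl or morpholin-4-yl would sit with pyrrolidin-1-yl, and whether a methyl on the amide nitrogen of butylamino would keep the number of compound 2 at 1330 nM.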